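The source may report more compounds than this note shows. Statements on the series, on what has been measured and on what is new or still open speak of the compounds shown alone.

Compound 1 `CCOC(=O)/C=C(C)/C=C/CC(C)CCCC(C)(C)OC` gives 5.54 in a physicochemical assay for lipophilicity; a lower number here means a more polar compound, a higher number a more lipophilic compound. For the measured compounds named here, compound 2 `COC(C)(C)CCCC(C)C/C=C/C(C)=C/C(=O)OC1CC1` gives 5.71 in this assay, the highest of the two numbers so far, with compound 1 nearest at a number 0.17 log units higher from compound 1 to compound 2 (within the scatter). Compound 3 `C=CCSC(=O)/C=C(C)/C=C/CC(C)CCCC(C)(C)OC` differs from compound 2 by allylsulfanyl in place of cyclopropyloxy on a carbonyl carbon. Going by the values given here, the single measured step, a number 0.17 log units higher from compound 1 to compound 2 (within the scatter), covers cyclopropyl in place of ethyl only and leaves the oxygen-to-sulfur exchange untested; no measured step bears on it. A rise beyond the scatter is nonetheless expected for compound 3, a number 0.49 log units higher from compound 2 to compound 3 (beyond the scatter). Compound 3 is therefore estimated at 6.2, within 5.7 to 6.7.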

Compound 3, partition coefficient: 6.77
Beside the measured number, compound 3's estimate is 0.57 log units below it, and the stated range ends below it.
By their numbers in this assay, from the lowest: compounds 1 and 2 (each within the scatter of the next); then compound 3.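

On this carbonyl carbon, the number in this assay proved sensitive to the group attached: allylsulfanyl gives a large rise over cyclopropyloxy (a number 1.06 log units higher from compound 2 to compound 3 (beyond the scatter)) and over ethoxy (a number 1.23 log units higher from compound 1 to compound 3 (beyond the scatter)). For the compounds shown here, the earlier change of the group on oxygen, from ethyl to cyclopropyl, stayed within the scatter, so the first sizeable step at this position comes with the change that brings in sulfur and the allyl chain together. No measurement at hand explains the size of this rise. On these data alone, how much of it belongs to the sulfur and how much to the allyl chain remains open. Allyloxy and cyclopropylsulfanyl on the same carbonyl carbon would separate the two.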